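Heptyl for vinyl on a second core

The compounds below may be only part of what the source reports. "The series", "measured", "known", "first", "only" and "open" are said of these compounds alone.

Measured so far:
compound 1, `C=CCOC(=O)NS(=O)(=O)Nc1cccc(-c2cc3ccccc3[nH]2)c1`, 15400 nM
compound 2, `C=CCOC(=O)NS(=O)(=O)Nc1cc(-c2cc3cc(F)ccc3[nH]2)ccc1OC`, 540 nM
compound 3, `CCCCCCCCOC(=O)NS(=O)(=O)Nc1cccc(-c2cc3ccccc3[nH]2)c1`, 1550 nM

All three were tested in an assay for inhibition of Polyunsaturated fatty acid lipoxygenase ALOX15 (Oryctolagus cuniculus), read by spectrophotometry; a lower number here means a stronger inhibitor, a higher number a weaker inhibitor. Compound 1 and compound 3 share a core and differ only in the ester chain: heptyl in place of vinyl on a saturated chain carbon bound to an oxygen next to a carbonyl group. That change gave a 9.9-fold lower number from compound 1 to compound 3 (1.00 log units; beyond the scatter). Compound 2 carries a different core; how the two cores differ is not broken down here, and compound 2 gives the lowest number of the three.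

Compound 4, `CCCCCCCCOC(=O)NS(=O)(=O)Nc1cc(-c2cc3cc(F)ccc3[nH]2)ccc1OC`, has not yet been measured. It is to compound 2 what compound 3 is to compound 1: heptyl in place of vinyl on a saturated chain carbon bound to an oxygen next to a carbonyl group. The place of the change is the same in both pairs, so this is the same kind of change made on a second core. Since the step is known only once, as a 9.9-fold lower number from compound 1 to compound 3 (1.00 log units; beyond the scatter), and the core of compound 2 is different, the step from compound 2 to compound 4 is expected to be somewhat smaller, roughly a 6.0-fold lower number from compound 2 to compound 4 (0.78 log units; beyond the scatter). Compound 4 is therefore estimated at 90 nM, between 25 nM and 320 nM.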

Compound 4, half-maximal inhibitory concentration: 47 nM
For compound 4 the middle estimate is 1.9-fold (0.28 log units) above the measured one, within the range that was stated.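

In this assay, putting heptyl in place of vinyl on the second core gave an 11-fold lower number from compound 2 to compound 4 (1.06 log units; beyond the scatter), and the two steps made by this change agree closely: the same change on two cores in this assay, a 9.9-fold lower number (1.00 log units; beyond the scatter) from compound 1 to compound 3 and an 11-fold lower number (1.06 log units; beyond the scatter) from compound 2 to compound 4, 1.2-fold (0.06 log units) apart, within the scatter of two such steps. In these two pairs, then, the longer chain lowered the number by about the same amount on either core, so the size of the step carried over from one core to the other. Within the data shown here, this rests on only two cores and a single swap of chains, so it does not show why the number falls, nor that the step would stay the same on other cores.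

The compounds shown leave open how the number changes with chains of other lengths in the same place, such as a butyl or a dodecyl chain, and whether a chain ending in an amine or a carboxylic acid would give a similar step. They also leave open which feature of the core of compound 2 matters on its own.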